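A few compounds are considered here, and "the series" means these few. Any claim that something is new, unique, unknown or untested is made for them only; others in the source may bear on it.

Measured compounds:
- Compound 1, `Cc1ccc(-c2cc3nc(-c4ccc(F)cc4)cc(N)n3n2)cc1`: 64.3%
- Compound 2, `Nc1cc(-c2ccc(Cl)cc2)nc2cc(-c3ccccc3)nn12`: 51.2%
- Compound 3, `Cc1ccc(-c2cc3nc(-c4ccc(Br)cc4)cc(N)n3n2)cc1`: 66.7%

In a functional assay on the whole organism (strain Wistar) for inhibition, with Rattus norvegicus as the target, read by paw edema, with stated times of 30 min and 4 h, at a dose of 50 mg/kg by the oral route (on this read-out lower numbers stand for less inhibition and higher numbers for more inhibition at the one dose given (going by the name of the read-out)), compound 3 gives 66.7%. This is the highest of the three numbers shown, yet compound 1 lies so close that the two cannot be told apart, whereas compound 2, at 51.2%, sits beyond the usual scatter below it.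

Compound 4, `Cc1ccc(-c2cc3nc(-c4ccc(Cl)cc4)cc(N)n3n2)cc1`, is the next compound in this series. It differs from compound 3 in one place only: chloro in place of bromo on an aromatic carbon.

Among the measured compounds shown here, only one measured step speaks to a change of this kind, because it too swaps one halogen for another at the same place: a number 2.4 percentage points higher from compound 1 to compound 3 (within the scatter). That step stayed within the scatter, so the halogen sitting at this position did not move the read-out in a way that could be distinguished from repeat measurements. Chloro being the third halogen of the same family, the same outcome is expected here: no step beyond the scatter, in either direction, that is a number 1.7 percentage points lower from compound 3 to compound 4 (within the scatter). Compound 4 is therefore estimated at 65%, with a likely range from 55% to 75%.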

Compound 4, a percentage reported as inhibition, in the whole organism at one dose (the size of the read-out at that dose, not a potency): 67.9%
Compound 4: the middle estimate sits 2.9 percentage points below what was measured, and the stated range covers the measured number.
By their numbers in this assay, from the lowest: compound 2; then compounds 1, 3 and 4 (each within the scatter of the next).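

In this assay, chloro in place of bromo gives a number 1.2 percentage points higher from compound 3 to compound 4 (within the scatter), and chloro in place of fluoro gives a number 3.6 percentage points higher from compound 1 to compound 4 (within the scatter). With fluoro, chloro and bromo now all seen on this aromatic carbon, no swap among these three halogens separates from repeat measurements, so the earlier single step between fluoro and bromo now has two more beside it. The new compound also adds a step of a different kind, at a different place on the molecule: methyl in place of hydrogen on an aromatic carbon gives a number 16.7 percentage points higher from compound 2 to compound 4 (beyond the scatter), a modest step that goes beyond the scatter while the 4-chlorophenyl group stays the same, although nothing at hand offers an explanation for either finding.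

All the groups seen at this position are halogens, so a methoxy group or a carboxylic acid there could behave quite differently from them. The methyl step also rests on a single pair of compounds, which leaves open whether it would hold with fluoro or bromo in place of chloro, and a single oral dose gives no measure of potency.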